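This account rests on a few compounds, and the source may have more. Where it says the series, first, only, none or still open, it means among the compounds named here.

Compound 1 `Nc1ccccc1C(=O)N/N=C/C1=C(Cl)c2ccccc2CCC1` reaches only the limit > 100000 nM in a functional assay on HeLa cells (Homo sapiens) for inhibition, read by sulforhodamine B assay, with a stated time of 48 h; on this read-out higher numbers stand for weaker inhibition of growth and lower numbers for stronger inhibition of growth; this is a limit, not a number. Compound 2 `O=C(N/N=C/C1=C(Cl)c2ccccc2CCC1)c1cccnc1` gives 7500 nM in this assay. The change is pyridin-3-yl in place of 2-aminophenyl on a carbonyl carbon, and the step is an at least 13-fold lower number from compound 1 to compound 2 (1.12 log units; beyond the scatter); as a measured step it rests on (the limit of > 100000 nM in this assay, at which 2 of the 3 values shown sit).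

Compound 3 `Cc1cc2c(cc1C)C(Cl)=C(/C=N/NC(=O)c1ccccc1N)CCC2` also returns the limit > 100000 nM in this assay; this too is a limit only. The difference between the core of compound 3 and the core of compound 1 is not broken down here.

Compound 4 `Cc1cc2c(cc1C)C(Cl)=C(/C=N/NC(=O)c1cccnc1)CCC2` is not yet measured. The change from compound 3 is pyridin-3-yl in place of 2-aminophenyl on a carbonyl carbon, the same change as seen before. Accordingly, a step of an at least 10-fold lower number from compound 3 to compound 4 (1.00 log units; beyond the scatter) is expected, resting on compound 2 and its value 7500 nM. Compound 4 is therefore estimated at 10000 nM, expected between 3000 nM and 60000 nM.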

Compound 4, concentration for 50% growth inhibition: 650 nM
Beside the measured number, compound 4's estimate is 15-fold (1.19 log units) above it; measured number outside the range, below it.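

On the core of compound 3, the change again gives a lower number in this assay, with an at least 150-fold lower number from compound 3 to compound 4 (2.18 log units; beyond the scatter). The direction therefore carries over from the core of compound 1 to the core of compound 3, but the two steps cannot be ranked by size: the same change on two cores in this assay, an at least 13-fold lower number (1.12 log units; beyond the scatter) from compound 1 to compound 2 and an at least 150-fold lower number (2.18 log units; beyond the scatter) from compound 3 to compound 4; the limit leaves it open whether they differ. Both steps start from a limit and not from a number, so neither gives the full size of the change: the limit of > 100000 nM in this assay, at which 2 of the 4 values shown sit.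

The compounds shown leave open whether the result follows from losing the amino group or from gaining the ring nitrogen, which a plain phenyl or a pyridin-4-yl on the carbonyl carbon would help separate. Also open, from the compounds shown here alone, is whether the change holds on a core carrying methoxy groups in place of the methyl groups.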